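Notes on a shared-core series: nitro for fluoro switch

The source may report more compounds than this note shows. Statements on the series, on what has been measured and on what is new or still open speak of the compounds shown alone.

Measured compounds:
- compound 1 `O=C1/C(=C\c2cc3ccccc3nc2Cl)c2ccccc2N1c1c(Cl)cccc1Cl` — "not determined" (no result reported) in a functional assay on MOLT-4 cells (Homo sapiens) for cytotoxicity, read by MTT assay, with a stated time of 72 h; on this read-out lower numbers stand for an effect already at smaller amounts and higher numbers for an effect only at larger amounts of compound
- compound 2 `O=C1/C(=C\c2ccc(F)cc2)c2ccccc2N1c1c(Cl)cccc1Cl` — "not determined" (no result reported) in this assay
- compound 3 `O=C1/C(=C\c2cccc(Oc3ccccc3)c2)c2ccccc2N1c1c(Cl)cccc1Cl` — 6 ug/mL in this assay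

Three compounds share the core; only compound 3 has a number in this assay, and it gives 6 ug/mL. Compound 2 stands without a number: its entry carries "not determined" (no result reported), and the same holds for compound 1, whose entry carries "not determined" (no result reported), so compound 2 cannot be placed against compound 3 on the numbers shown. Among the compounds with values here, no pair of measured compounds differs in one place, so no step between measured compounds is available.

Compound 4 `O=C1/C(=C\c2ccccc2[N+](=O)[O-])c2ccccc2N1c1c(Cl)cccc1Cl` is the compound yet to be measured. It differs from compound 2 in one place: 2-nitrophenyl in place of 4-fluorophenyl on a double-bonded chain carbon bound to a double-bonded ring carbon. Within the data shown here, the size and direction of the step from compound 2 to compound 4 in this assay cannot be taken from the data, as compound 2 has no number, and no measured step of any kind is available to carry over. Among the measured compounds shown here, the expectation therefore rests on the one number, from compound 3, with wide bounds. Compound 4 is expected to give an estimate of 8 ug/mL, with a range from 2 ug/mL to 30 ug/mL.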

Compound 4, concentration for half-maximal effect: 6 ug/mL
The estimate for compound 4 lay 1.3-fold (0.12 log units) above the measured number, within the range that was stated.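

Within the data shown here, compound 2 has no single number in this assay, so no step from it to compound 4 can be read. The compounds shown leave open whether 2-nitrophenyl in place of 4-fluorophenyl changes the result in this assay at all, and in which direction. No data bearing on a cause are available here.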